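Notes on the step from compound 3 to compound 4

The compounds below may be only part of what the source reports. "The series", "measured", "known", "first", "only" and "open" are said of these compounds alone.

Measured so far in a functional assay on A498 cells (Homo sapiens) for inhibition (a higher number here means a weaker inhibitor of growth, a lower number a stronger inhibitor of growth), for three compounds:
- compound 1 `COc1cc(/C=C/C(=O)c2cccc(-n3cc(-c4ccc(Cl)cc4)[nH]c3=O)c2)cc(OC)c1OC` gives 30200 nM here
- compound 2 `O=C(/C=C/c1cccc(O)c1)c1cccc(-n2cc(-c3ccccc3)[nH]c2=O)c1` gives 14300 nM here
- compound 3 `O=C(/C=C/c1cccc(O)c1)c1cccc(-n2cc(-c3ccc(Cl)cc3)[nH]c2=O)c1` gives 3710 nM here

Compound 3 has the lowest number of the three, with compound 2 nearest and compound 1 furthest. The next compound is compound 4 `COc1cc(/C=C/C(=O)c2cccc(-n3cc(-c4ccc(Cl)cc4)[nH]c3=O)c2)ccc1O`, and its difference from compound 3 is 4-hydroxy-3-methoxyphenyl in place of 3-hydroxyphenyl on a double-bonded chain carbon bound to a double-bonded chain carbon on the same shared core. Among the compounds with values here, the only measured step, a 3.9-fold lower number from compound 2 to compound 3 (0.59 log units; beyond the scatter), is a modest one, a chloro in place of hydrogen on an aromatic carbon. Compound 4 keeps that chloro, so this step does not test the new change. Within the data shown here, no measured step covers the change directly. The nearest guide is the gap between compound 1 at 30200 nM and compound 3 at 3710 nM in this assay as a sign of how far values spread among the chloro compounds. A modest move to a higher number is therefore expected, with wide uncertainty. The expected change is a 1.8-fold higher number from compound 3 to compound 4 (0.24 log units; within the scatter) as an estimate only. For compound 4 the estimated value is 6500 nM with an expected range from 2000 nM to 20000 nM in all.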

Compound 4, concentration for 50% growth inhibition: 2820 nM
Beside the measured number, compound 4's estimate is 2.3-fold (0.36 log units) above it, and the stated range covers the measured number.
By their numbers in this assay, from the lowest: compounds 4 and 3 (each within the scatter of the next); then compound 2; then compound 1.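

In this assay this position accepts the exchange of 3-hydroxyphenyl for 4-hydroxy-3-methoxyphenyl without a readable shift, with a 1.3-fold lower number from compound 3 to compound 4 (0.12 log units; within the scatter). The two groups are therefore not told apart here, although the entering group carries an added methoxy and its hydroxy sits elsewhere on the ring, while compound 1, whose group at this place has no hydroxy, gives 30200 nM and compound 4 gives 2820 nM. No measured evidence bears on why the two groups read alike.

As far as these compounds go, whether the hydroxy is what separates compound 1 from compound 4 stays open, and an amine in its place would put that to the test. Also open, from the compounds shown here alone, is whether the same exchange reads alike on a core without the chloro.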